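The source may report more compounds than this note shows. Statements on the series, on what has been measured and on what is new or still open speak of the compounds shown alone.

Measured so far in an assay for inhibition of steroid 17-alpha-hydroxylase/17,20 lyase (Homo sapiens), using NADPH, tested at 0.2 uM; a higher number here means a stronger effect of the compound at the concentration tested, a lower number a weaker effect:
- compound 1, `COc1ccc(-c2csc(Cn3ccnc3)c2)cc1`: 0%
- compound 2, `CCC(c1cc(-c2ccc(F)c(F)c2)cs1)n1ccnc1`: 17%
- compound 3, `Fc1ccc(-c2csc(Cn3ccnc3)c2)cc1F`: 7%

On these numbers compound 3 holds the middle place of the three, yet its gap to compound 1 and its gap to compound 2 both lie within the usual scatter, so none of the three can be told apart with confidence.

Compound 4, `Fc1ccc(-c2csc(Cn3ccnc3)c2)cc1`, differs from compound 3 in one place: hydrogen in place of fluoro on an aromatic carbon. Among the compounds with values here, the only measured step, a number 10 percentage points lower from compound 2 to compound 3 (within the scatter), concerns hydrogen in place of ethyl on a saturated chain carbon and is of a different kind, so it offers no direct guide to removing a fluoro group. Compound 1 and compound 3 differ in more than one place, so their two values show only that both are small. With every measured number low and every gap within the scatter, the expectation is that compound 4 remains in the same low range, with a number 2 percentage points lower from compound 3 to compound 4 (within the scatter) expected to stay within the scatter. Compound 4 is therefore estimated at 5% in this assay, between -5% and 18%.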

Compound 4, a percentage reported as inhibition, at one concentration (the size of the read-out at that concentration, not a potency): 0%
Beside the measured number, compound 4's estimate is 5 percentage points above it; the range from low to high includes it.
By their numbers in this assay, from the lowest: compounds 1, 4, 3 and 2 (each within the scatter of the next, the first and the last beyond it).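

In this assay, replacing one fluoro group with hydrogen, on an aromatic carbon ortho to a fluoro group and meta to a large group, gives a number 7 percentage points lower from compound 3 to compound 4 (within the scatter) and so leaves the two compounds indistinguishable at this single concentration. A second kind of change, fluoro in place of methoxy on an aromatic carbon, gives no change at the digits printed from compound 1 to compound 4 (within the scatter) and likewise shows no readable difference. Nothing measured here explains either result.

Within the data shown here, whether this position can respond at all remains open, since hydrogen and fluoro are the only groups compared there, and an amine or a carboxylic acid at that carbon might read differently. Among these compounds, also open is whether the ethyl group on the chain carbon of compound 2 would give a different number with the single fluoro group of compound 4.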